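Swapping the chain end: compound 3 to compound 4

The source may hold more compounds than are shown below. What is called first, only, known or untested is meant among the compounds shown, and "the series" means these compounds.

In a functional assay (trachea) with Cavia porcellus as the target (on this read-out lower numbers stand for an effect already at smaller amounts and higher numbers for an effect only at larger amounts of compound), compound 1 `CCCn1c(=O)n(CCC(N)=O)c(=O)c2[nH]cnc21` gives 13100 nM while compound 2 `CCCn1c(=O)n(CCC#N)c(=O)c2[nH]cnc21` gives 1700 nM and compound 3 `CCCn1c(=O)n(CCCN(C)C)c(=O)c2[nH]cnc21` gives 20500 nM on the shared core. Compound 3 stands at the high end of these numbers together with compound 1: the step of a 1.6-fold higher number from compound 1 to compound 3 (0.19 log units; within the scatter) stays within the scatter, whereas a 12-fold higher number from compound 2 to compound 3 (1.08 log units; beyond the scatter) is large and beyond it.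

Compound 4 `CCCn1c(=O)n(CCOC)c(=O)c2[nH]cnc21` carries methoxy in place of (dimethylamino)methyl on a saturated chain carbon, two bonds along the chain from an aromatic nitrogen. For the measured compounds named here, no measured step makes this exact exchange, so the evidence is indirect. Compound 2 lacks the (dimethylamino)methyl group, as compound 4 does, and the large step of a 12-fold higher number from compound 2 to compound 3 (1.08 log units; beyond the scatter) read backwards points to a lower number. Compound 1 lacks that group too and goes against this reading, since a 1.6-fold higher number from compound 1 to compound 3 (0.19 log units; within the scatter) shows no change beyond the scatter. The same place also responds in the modest step of a 7.7-fold lower number from compound 1 to compound 2 (0.89 log units; beyond the scatter) between the two compounds without that group. A step of intermediate size towards a lower number is therefore expected in this assay and the estimated change is a 4.6-fold lower number from compound 3 to compound 4 (0.66 log units; beyond the scatter) on this evidence. Compound 4 is estimated at 4500 nM with an expected range from 1300 nM to 14000 nM in this read-out.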

Compound 4, half-maximal effective concentration: 700 nM
The estimate for compound 4 lay 6.4-fold (0.81 log units) above the measured number, and the stated range ends above it.
By their numbers in this assay, from the lowest: compound 4; then compound 2; then compounds 1 and 3 (each within the scatter of the next).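

For the compounds shown here, at this place, on a saturated chain carbon, two bonds along the chain from an aromatic nitrogen, methoxy is the first end group to pass the nitrile in this assay, with a 2.4-fold lower number from compound 2 to compound 4 (0.39 log units; beyond the scatter), and it also stands well clear of carbamoyl, with a 19-fold lower number from compound 1 to compound 4 (1.27 log units; beyond the scatter), so compound 4 has the lowest number of the four. The exchange of (dimethylamino)methyl for methoxy gives a 29-fold lower number from compound 3 to compound 4 (1.47 log units; beyond the scatter), the widest step yet seen at this place, although the two groups have the same computed counts of hydrogen-bond donors and acceptors and the same net charge, so those counts do not track the change, and what differs is the atoms themselves and the number of heavy atoms. Nothing on hand explains any of these steps.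

The compounds shown leave open whether the low number goes with the ether oxygen or with the short end group; a hydroxyl, an ethoxy group or a plain alkyl chain at the same place would separate the two. On these data alone, it also remains open whether a longer chain between the aromatic nitrogen and the methoxy keeps the gain in this assay.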